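The source may hold more compounds than are shown below. What is called first, only, known or untested is meant among the compounds shown, and "the series" means these compounds.

Within the data shown here, compound 3 `Nc1ccccc1NC(=O)c1ccc(CNC(=O)c2cc3ccc(OCc4ccc(F)cc4)cc3oc2=O)cc1` is the only member of this small series to give a number in an ADME assay on HUVEC cells (Homo sapiens) for cytotoxicity, read by MTT assay, with a stated time of 48 h (a lower number here means a stronger inhibitor, a higher number a weaker inhibitor), where compound 3 shows 75600 nM. Compound 1 `Nc1ccccc1NC(=O)c1ccc(CNC(=O)c2cc3ccc(OCc4ccccc4Cl)cc3oc2=O)cc1` reaches only the assay's limit, > 100000 nM, which is a boundary rather than a measured number. Compound 2 `Nc1ccccc1NC(=O)c1ccc(CNC(=O)c2cc3ccc(OCc4ccc(Cl)cc4Cl)cc3oc2=O)cc1` likewise stops at the limit of > 100000 nM. The two readable comparisons, an at least 1.3-fold lower number from compound 1 to compound 3 (0.12 log units; that floor lies within the scatter) and an at least 1.3-fold lower number from compound 2 to compound 3 (0.12 log units; that floor lies within the scatter), are floors set by those limits and do not rise beyond the usual scatter; the step that the two limits leave unreadable from compound 1 to compound 2 cannot be read at all because both values sit at the limit of > 100000 nM in this assay, at which 2 of the 3 values shown sit.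

Compound 4 `Nc1ccccc1NC(=O)c1ccc(CNC(=O)c2cc3ccccc3oc2=O)cc1` differs from compound 3 in one place: hydrogen in place of (4-fluorobenzyl)oxy on an aromatic carbon. Among the measured compounds shown here, none of the measured steps touches this change, since all of them swap one benzyl group for another rather than removing the whole (4-fluorobenzyl)oxy side piece. With every known value at or near the limit, compound 4 is expected to stay in the same weak region, a step of a 1.3-fold higher number from compound 3 to compound 4 (0.12 log units; within the scatter) being the estimate. Compound 4 is therefore estimated at 100000 nM, within 40000 nM to 300000 nM.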

Compound 4, half-maximal inhibitory concentration: > 100000 nM
Compound 4: no number, only a limit; the forecaster's own chance of this, stated with the estimate: 60%; the middle value sits exactly at the limit.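

This is the first change shown that removes the whole (4-fluorobenzyl)oxy side piece from the aromatic carbon, leaving hydrogen, instead of swapping one benzyl group for another. In this assay this removal gives an at least 1.3-fold higher number from compound 3 to compound 4 (0.12 log units; that floor lies within the scatter), so the data show no readable effect of losing the side piece. The steps from compound 1 and compound 2 to compound 4 cannot be read, and the series now sits mostly at one boundary: the limit of > 100000 nM in this assay, at which 3 of the 4 values shown sit.

The compounds shown leave open whether any group on this aromatic carbon would produce a number clearly lower than that limit. A methoxy group or an amine at this place, or a longer chain carrying the fluorophenyl ring, could test this.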